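A few compounds are considered here, and "the series" means these few. Any claim that something is new, unique, unknown or untested is made for them only; others in the source may bear on it.

Of the compounds shown here, three built on one shared core have been tested in a functional assay on MCF7 cells (Homo sapiens) for antiproliferative activity, read by MTT assay, with a stated time of 72 h (a higher number here means a weaker inhibitor, a lower number a stronger inhibitor), and they differ only in the substituted phenyl group they carry. Compound 1 `COc1cc(-n2cnc3ccc(-c4ccccc4Cl)cc32)cc(OC)c1OC`, with a 2-chlorophenyl group, gives > 10000 nM, which is a limit of the assay and not a number. Compound 2 `COc1cc(-n2cnc3ccc(-c4ccc(C)cc4)cc32)cc(OC)c1OC`, with a 4-methylphenyl group, gives 110 nM. Compound 3 `COc1cc(-n2cnc3ccc(-c4ccc(Cl)cc4)cc32)cc(OC)c1OC`, with a 4-chlorophenyl group, gives 1320 nM, the higher of the two actual numbers, which makes it the weaker inhibitor of that pair.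

Compound 4 `COc1cc(-n2cnc3ccc(-c4ccc(F)cc4)cc32)cc(OC)c1OC` is still unmeasured. It has fluoro in place of chloro on an aromatic carbon, para to a large group: fluoro in place of chloro on an aromatic carbon.

The closest guide is a 12-fold higher number from compound 2 to compound 3 (1.08 log units; beyond the scatter), a large change from one small group to another at this same place. The other two steps, an at least 90-fold lower number from compound 1 to compound 2 (1.95 log units; beyond the scatter) and an at least 7.5-fold lower number from compound 1 to compound 3 (0.87 log units; beyond the scatter), start from a limit and involve the 2-chlorophenyl group, so they say less about this swap. Among the compounds with values here, no fluoro compound has been measured, so the direction cannot be read from the data. The expected change is modest, a 1.7-fold lower number from compound 3 to compound 4 (0.22 log units; within the scatter), with no firm shift beyond the scatter, although the large step seen for compound 3 keeps the range wide. For compound 4 the estimate is 800 nM, with an expected range from 200 nM to 3500 nM.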

Compound 4, half-maximal inhibitory concentration: 1770 nM
The estimate for compound 4 lay 2.2-fold (0.34 log units) below the measured number; the measured number falls inside the stated range.
By their numbers in this assay, from the lowest: compound 2; then compounds 3 and 4 (each within the scatter of the next). At a limit, above all of these: compound 1.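

In this assay fluoro in place of chloro gives a 1.3-fold higher number from compound 3 to compound 4 (0.13 log units; within the scatter) so this position does not separate these two groups, even though the earlier step between methyl and chloro, a 12-fold higher number from compound 2 to compound 3 (1.08 log units; beyond the scatter) was large. Methyl now stands apart from fluoro as well, with a 16-fold higher number from compound 2 to compound 4 (1.21 log units; beyond the scatter) so compound 2 sits clear of both compound 3 and compound 4, and the effect of this position no longer rests on a single comparison. The step to the 4-fluorophenyl group from the 2-chlorophenyl group, an at least 5.6-fold lower number from compound 1 to compound 4 (0.75 log units; beyond the scatter) can be given only as a bound, because the value for compound 1 is a limit of the assay and not a number: the limit of > 10000 nM in this assay, at which 1 of the 4 values shown sits.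

The compounds shown leave open whether a longer chain, an amine or a carboxylic acid at this position would match compound 2 or fall back towards compound 3 and compound 4. They also leave open whether a 2-methylphenyl or 2-fluorophenyl group would sit as high in this assay as the 2-chlorophenyl group of compound 1.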